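Fluorinated aryl ureas: a second fluoro on the anilide ring

A few compounds are considered here, and "the series" means these few. Any claim that something is new, unique, unknown or untested is made for them only; others in the source may bear on it.

Compound 1 `C[C@@H](NC(=O)Nc1cccc(F)c1)c1ccccc1` and compound 2 `C[C@H](NC(=O)Nc1cccc(F)c1)c1ccccc1` have the same atoms and bonds and differ only in configuration as drawn: the two compounds have the same atoms and bonds and differ only in configuration as drawn: 1 of 1 stereo elements differ; a stereocentre at a saturated chain carbon is drawn S in compound 2 and R in compound 1. In an ADME assay on the whole organism with Oryza sativa as the target, tested at 0.1 uM (a higher number here means a weaker effect of the compound at the concentration tested, a lower number a stronger effect), compound 1 gives 99% and compound 2 gives 97%, a step of a number 2 percentage points lower from compound 1 to compound 2 (within the scatter). That the two values lie so close is consistent with the fact that compounds 1 and 2 differ only in the configuration as drawn. Compound 3 `C[C@H](NC(=O)Nc1cccc(F)c1F)c1ccccc1` carries one more fluoro than compound 2: fluoro in place of hydrogen on an aromatic carbon. In this assay compound 3 gives 100%, a step of a number 3 percentage points higher from compound 2 to compound 3 (within the scatter). Both measured steps lie within the scatter, so the three compounds cannot be ordered against each other.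

Compound 4 `C[C@@H](NC(=O)Nc1cc(F)cc(F)c1)c1ccccc1` is not yet measured. It arises from compound 1 by fluoro in place of hydrogen on an aromatic carbon. Going by the values given here, this is the same kind of change as the one from compound 2 to compound 3, but not the same: there the incoming fluoro sits ortho to a fluoro group and ortho to a large group, here it sits meta to a fluoro group and meta to a large group. Compound 4 is expected to show a step of no change at the digits printed from compound 1 to compound 4 (within the scatter), beside the measured a number 3 percentage points higher from compound 2 to compound 3 (within the scatter). That expectation rests on compound 3 giving 100% after the same kind of change, and on compound 1 already giving 99%, which leaves little room for the number to move upward. Compound 4 is therefore estimated at 99% in this assay, within 93% to 100%.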

Compound 4, a percentage reported as activity, at one concentration (the size of the read-out at that concentration, not a potency): 98%
The estimate for compound 4 lay 1 percentage points above the measured number; low and high end bracket the measured number.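

In this assay, fluoro in place of hydrogen on an aromatic carbon, here meta to a fluoro group and meta to a large group, gives a number 1 percentage points lower from compound 1 to compound 4 (within the scatter). Set beside the earlier case on the other core, the two steps do not differ: the same change on two cores in this assay, a number 3 percentage points higher (within the scatter) from compound 2 to compound 3 and a number 1 percentage points lower (within the scatter) from compound 1 to compound 4, 4 percentage points apart, within the scatter of two such steps This shows that in both cases the change leaves the number within the scatter on these two cores, but it does not show a transferable effect, as neither step can be told from no change, and the two pairs differ both in where the incoming fluoro sits and in the configuration as drawn at the saturated chain carbon.

As far as these compounds go, it remains open whether a group other than fluoro on the aromatic ring, such as an amine or a carboxylic acid, or a longer chain at the saturated chain carbon, would move the number in this assay beyond the scatter. Also open, from the compounds shown here alone, is how the change reads with the incoming fluoro in one and the same place on both configurations as drawn, a comparison that would separate place from configuration.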